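The compounds below may be only part of what the source reports. "The series", "measured", "known", "first", "only" and "open" are said of these compounds alone.

Compounds measured in a functional assay on HepG2 cells (Homo sapiens) for inhibition, read by MTT assay, with a stated time of 48 h; on this read-out higher numbers stand for weaker inhibition and lower numbers for stronger inhibition:
- compound 1 `COc1ccc(/C=N/NC(=O)CSc2nnc(-c3ccncc3)n2-c2ccccc2)cc1` gives 27100 nM
- compound 2 `O=C(CSc1nnc(-c2ccncc2)n1-c1ccccc1)N/N=C/c1cccc(F)c1` gives 24400 nM
- compound 3 `O=C(CSc1nnc(-c2ccncc2)n1-c1ccccc1)N/N=C/c1cc(Br)ccc1O` gives 4390 nM

Compound 3 stands lowest of the three; the step of a 6.2-fold lower number from compound 1 to compound 3 (0.79 log units; beyond the scatter) and the step of a 5.6-fold lower number from compound 2 to compound 3 (0.74 log units; beyond the scatter) both lie beyond the scatter, while a 1.1-fold lower number from compound 1 to compound 2 (0.05 log units; within the scatter) does not. Compound 4 `O=C(CSc1nnc(-c2ccncc2)n1-c1ccccc1)N/N=C/C=C/c1ccccc1` differs from compound 3 by 2-phenylethenyl in place of 5-bromo-2-hydroxyphenyl on a carbon with a double bond to nitrogen. The two steps into compound 3 bear on this change, since both replaced a plain aromatic ring with the 5-bromo-2-hydroxyphenyl group and both lowered the number modestly. Taking that group away again is therefore expected to raise the number, roughly back to where compounds 1 and 2 sit. The expected step is a 4.6-fold higher number from compound 3 to compound 4 (0.66 log units; beyond the scatter). Compound 4 is estimated at 20000 nM, within a range from 8000 nM to 50000 nM.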

Compound 4, half-maximal inhibitory concentration: 8280 nM
Compound 4: the middle estimate sits 2.4-fold (0.38 log units) above what was measured, and the stated range covers the measured number.
By their numbers in this assay, from the lowest: compounds 3 and 4 (each within the scatter of the next); then compounds 2 and 1 (each within the scatter of the next).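

In this assay, the 5-bromo-2-hydroxyphenyl group is not needed for a low number at this position: the step with 2-phenylethenyl in its place stays within the scatter (a 1.9-fold higher number from compound 3 to compound 4 (0.28 log units; within the scatter)). The 2-phenylethenyl group also gives a lower number than either of the other two rings (a 2.9-fold lower number from compound 2 to compound 4 (0.47 log units; beyond the scatter); a 3.3-fold lower number from compound 1 to compound 4 (0.51 log units; beyond the scatter)). No measurement here explains these steps. Still open, from the compounds shown here alone, is whether the double bond outside the ring matters, which 2-phenylethyl at this position would test. Also open, going by these compounds, is whether the bromine or the hydroxyl carries the drop seen with compound 3, and what an amine on the ring would do.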